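This account rests on a few compounds, and the source may have more. Where it says the series, first, only, none or still open, it means among the compounds named here.

Compound 1 `O=C(N/N=C\c1cn(Cc2ccc(Cl)cc2)c2cc(F)ccc12)c1c[nH]c2ccccc12`: 18600 nM; compound 2 `Cn1cc(C(=O)N/N=C\c2cn(Cc3ccc(Cl)cc3)c3cc(F)ccc23)c2ccccc21`: 84200 nM; compound 3 `COc1ccc(Cn2cc(/C=N\NC(=O)c3c[nH]c4ccc(Br)cc34)c3ccc(F)cc32)cc1`: 67500 nM.

In a functional assay on DU-145 cells (Homo sapiens) for cytotoxicity (on this read-out lower numbers stand for stronger inhibition and higher numbers for weaker inhibition), compound 3 gives 67500 nM, the second highest of the three numbers; compound 2 gives a number within the scatter of it, while compound 1 gives a clearly lower number. Compound 4 `O=C(N/N=C\c1cn(Cc2ccc(Cl)cc2)c2cc(F)ccc12)c1c[nH]c2ccc(Br)cc12` differs from compound 3 by chloro in place of methoxy on an aromatic carbon. Among the measured compounds shown here, the only measured step, a 4.5-fold higher number from compound 1 to compound 2 (0.66 log units; beyond the scatter), concerns a different position and does not bear on this change. From the compounds shown here alone, compound 1 and compound 3 differ in two places at once, so the chloro-for-methoxy swap alone is untested. Compound 4 is expected to move partly toward compound 1, so a modest step of a 2.3-fold lower number from compound 3 to compound 4 (0.35 log units; beyond the scatter) toward a lower number is estimated. Compound 4 is estimated at 30000 nM, between 9000 nM and 100000 nM.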

Compound 4, half-maximal inhibitory concentration: 12500 nM
Beside the measured number, compound 4's estimate is 2.4-fold (0.38 log units) above it; low and high end bracket the measured number.
By their numbers in this assay, from the lowest: compounds 4 and 1 (each within the scatter of the next); then compounds 3 and 2 (each within the scatter of the next).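

In this assay, among the compounds shown here, going from 4-methoxybenzyl to 4-chlorobenzyl gives a 5.4-fold lower number from compound 3 to compound 4 (0.73 log units; beyond the scatter) with the bromo group held in place, the first direct reading of this change at this position. Bromo in place of hydrogen gives a 1.5-fold lower number from compound 1 to compound 4 (0.17 log units; within the scatter) and so does not separate the two chloro compounds. The step of 5-bromo-1H-indol-3-yl in place of 1-methyl-1H-indol-3-yl gives a 6.7-fold lower number from compound 2 to compound 4 (0.83 log units; beyond the scatter) and shows that this chloro pair stays apart from the methylated compound. Nothing shown here explains these steps. Open, from the compounds shown here alone, are how fluoro, an amine or a carboxylic acid would read at this position, and whether the chloro-for-methoxy step holds without the bromo group.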